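The compounds below may be only part of what the source reports. "The series", "measured", "known", "first", "only" and "open" are said of these compounds alone.

Working notes on the series, read in a functional assay on HepG2 cells (Homo sapiens) for inhibition, read by MTT assay; a lower number here means a stronger inhibitor of growth, a higher number a weaker inhibitor of growth. Compound 1 (`COc1cc2oc(-c3cccc(NC(=O)c4ccccc4Br)c3)cc(=O)c2c(OC)c1OC`) gives 23100 nM, and compound 2 (`COc1cc2oc(-c3cccc(NC(=O)c4ccc([N+](=O)[O-])cc4)c3)cc(=O)c2c(OC)c1OC`) gives 18800 nM. These two values lie within the scatter of each other, so compound 2 stands level with compound 1 and no order can be drawn between them.

Next is compound 3 (`COC(=O)c1ccc(C(=O)Nc2cccc(-c3cc(=O)c4c(OC)c(OC)c(OC)cc4o3)c2)cc1`), which keeps the shared core and the amide of compound 2 and differs in one group: methoxycarbonyl in place of nitro on an aromatic carbon. In words, methoxycarbonyl takes the place of nitro on an aromatic carbon.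

Among the measured compounds shown here, only one measured step bears on this change: a 1.2-fold lower number from compound 1 to compound 2 (0.09 log units; within the scatter). That step alters the same aromatic group on the carbonyl carbon and stays within the scatter. For the measured compounds named here, no measured step replaces the nitro group itself, so the data give no direct reading of this swap. With that single step as the guide, no change beyond the scatter is expected in this assay, in either direction.

The estimated step is a 1.1-fold higher number from compound 2 to compound 3 (0.03 log units; within the scatter). For compound 3 the expected value is 20000 nM, with an estimated range of 9000 nM to 45000 nM.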

Compound 3, concentration for 50% growth inhibition: > 100000 nM
Compound 3: only a limit was reported; the forecaster's own chance of this, stated with the estimate: 8%; at least 5.0-fold (0.69 log units) between middle value and limit.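

Compound 3 is reported only as a limit of the assay, not as a number: the limit of > 100000 nM in this assay, at which 1 of the 3 values shown sits. Even so, the place on the aromatic ring para to a large group proves sensitive in this assay, where methoxycarbonyl in place of nitro gives an at least 5.3-fold higher number from compound 2 to compound 3 (0.72 log units; beyond the scatter), although the earlier change of the aromatic group on the carbonyl carbon stayed within the scatter. The other comparison agrees, with 4-(methoxycarbonyl)phenyl in place of 2-bromophenyl giving an at least 4.3-fold higher number from compound 1 to compound 3 (0.63 log units; beyond the scatter), so among the three compounds the group 4-(methoxycarbonyl)phenyl is the one that separates from the others, while 2-bromophenyl and 4-nitrophenyl stand level.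

On these data alone, the true size of both new steps stays open, since each rests on a limit and shows only how large the step must at least be. The compounds shown also do not tell whether this drop in growth inhibition belongs to methoxycarbonyl alone or extends to other groups at this place, such as a carboxylic acid, a carboxamide or an amine.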